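Carboxyphenoxy isomers on a shared tricyclic amide core

The source may report more compounds than this note shows. Statements on the series, on what has been measured and on what is new or still open speak of the compounds shown alone.

Compound 1 `Cc1ccccc1-n1nc(C)c2c1NC(=O)[C@H](C)S[C@@H]2c1ccc(Oc2ccccc2C(=O)O)cc1` is reported in an assay on isolated protein for agonist activity at Bile acid receptor (Homo sapiens), read by AlphaScreen, with a stated time of 30 min (a higher number here means that more compound is needed for the effect, a lower number that less compound is needed), as "not active" (no number reported), so no single number fixes where it stands. Compound 2 `Cc1nn(-c2ccccc2Cl)c2c1C(c1ccc(Oc3ccccc3)cc1)SC(C)C(=O)N2`, which carries a plain phenoxy group and a different aryl on the core, gives 2700 nM in this assay. Compound 3 `Cc1ccccc1-n1nc(C)c2c1NC(=O)[C@H](C)S[C@@H]2c1ccc(Oc2ccc(C(=O)O)cc2)cc1` differs from compound 1 only in the ring position of the acid (4-carboxyphenyl in place of 2-carboxyphenyl on an oxygen on an aromatic ring). Within the data shown here, no measured step covers this change; a moderate gain over compound 1, beyond the scatter, is expected, since compound 2 already reads 2700 nM without the acid. Compound 3 is estimated at 3000 nM in this assay, within 500 nM to 30000 nM.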

Compound 3, half-maximal effective concentration: "not active" (no number reported)
For compound 3 the study gives words and no number; there is nothing to compare the estimate with.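

With compound 1 and compound 3 both reported without a number in this assay, no step can be read between them. The compounds shown leave open whether any carboxyphenoxy isomer on the shared core reaches a measurable value. No evidence bears on this result.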